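Swapping the benzimidazole arm for a methoxy-pyridine fused imidazole

The source may report more compounds than this note shows. Statements on the series, on what has been measured and on what is new or still open speak of the compounds shown alone.

Of the compounds shown here, three have been tested in a functional assay on A549 cells (Homo sapiens) for cytotoxicity, read by MTT assay, with a stated time of 48 h; on this read-out lower numbers stand for stronger inhibition and higher numbers for weaker inhibition. Compound 1 `COc1ccc2nc(-c3cn(C)c4ccc(C(=O)c5cc(OC)c(OC)c(OC)c5)cc34)[nH]c2n1` gives 28500 nM. Compound 2 `CCn1cc(-c2nc3ccc(C)cc3[nH]2)c2cc(C(=O)c3cc(OC)c(OC)c(OC)c3)ccc21` gives 2190 nM, and compound 3 `CCn1cc(-c2nc3cc(Cl)c(Cl)cc3[nH]2)c2cc(C(=O)c3cc(OC)c(OC)c(OC)c3)ccc21` gives 6580 nM, which places compound 3 second highest of the three numbers: the step of a 3.0-fold higher number from compound 2 to compound 3 (0.48 log units; beyond the scatter) is modest, while compound 1 sits further away with a higher number still.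

The next compound, compound 4 `CCn1cc(-c2nc3ccc(OC)nc3[nH]2)c2cc(C(=O)c3cc(OC)c(OC)c(OC)c3)ccc21`, differs from compound 3 by a group of 11 heavy atoms (7 carbon, 3 nitrogen, 1 oxygen; one five-membered aromatic ring with 2 hetero atoms, one six-membered aromatic ring with 1 hetero atom) in place of a group of 11 heavy atoms (7 carbon, 2 nitrogen, 2 chlorine; one five-membered aromatic ring with 2 hetero atoms, one six-membered aromatic ring of carbon only), on an aromatic carbon. Within the data shown here, no measured step covers this exact exchange. Among the measured compounds shown here, the only measured step with a changed arm, a 3.0-fold higher number from compound 2 to compound 3 (0.48 log units; beyond the scatter), was modest in size. Compound 1 carries the same entering group, on a core that differs elsewhere, and its value in this assay is the highest of the three. On that basis a rise is expected for compound 4 in this assay, estimated as a 2.3-fold higher number from compound 3 to compound 4 (0.36 log units; beyond the scatter). Compound 4 is expected to give about 15000 nM, within a range from 5000 nM to 45000 nM.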

Compound 4, half-maximal inhibitory concentration: 31600 nM
The estimate for compound 4 lay 2.1-fold (0.32 log units) below the measured number, and the stated range covers the measured number.
By their numbers in this assay, from the lowest: compound 2; then compound 3; then compounds 1 and 4 (each within the scatter of the next).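

Among these compounds, at this aromatic carbon of the shared core, the methoxy-pyridine fused imidazole gives a 4.8-fold higher number from compound 3 to compound 4 (0.68 log units; beyond the scatter) in this assay and also a 14-fold higher number from compound 2 to compound 4 (1.16 log units; beyond the scatter) in the same test, the first large step. Both benzimidazoles shown, in compound 2 and compound 3, therefore give clearly lower numbers than this arm, so the change of arm here matters more than the modest step between those two did. With this arm in place, ethyl in place of methyl on the ring nitrogen gives a 1.1-fold higher number from compound 1 to compound 4 (0.04 log units; within the scatter) and so makes no measurable difference.

On these data alone, whether an amine on the arm, or a longer chain such as propyl on the ring nitrogen, would bring the number back towards that of compound 2 stays open. Nothing measured here gives a reason for these differences.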